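Removing the Hydroxymethyl Group from Compound 2

This account rests on a few compounds, and the source may have more. Where it says the series, first, only, none or still open, it means among the compounds named here.

Compound 2 `OCC#CCSc1cnc2ccccc2c1SCC#CCCl` stands highest of the three compounds measured in a functional assay on SW707 cells (Homo sapiens) for antiproliferative activity, with a stated time of 72 h (on this read-out higher numbers stand for weaker inhibition and lower numbers for stronger inhibition), with 19.8 ug/mL. Compound 3 `OCC#CCSc1cnc2ccccc2c1Cl` gives 6.2 ug/mL, and compound 1 `C#CCSc1cnc2ccccc2c1[Se]CC#CCCl` gives 3.2 ug/mL. Among the compounds with values here, the only measured one-place step, a 3.2-fold lower number from compound 2 to compound 3 (0.50 log units; beyond the scatter), concerns a different change and so does not bear directly on the move to compound 4 `C#CCSc1cnc2ccccc2c1SCC#CCCl`, which is hydrogen in place of hydroxymethyl on a triple-bonded carbon. Compound 1, which also carries the propargyl group, shows a lower number than compound 2 but differs from it at a second place as well, so no step can be read from that pair. Compound 4 is therefore expected to give a modest downward step a 2.5-fold lower number from compound 2 to compound 4 (0.39 log units; beyond the scatter), with an estimated value of 8 ug/mL in a range from 3 ug/mL to 25 ug/mL.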

Compound 4, concentration for 50% inhibition: 12.9 ug/mL
The estimate for compound 4 lay 1.6-fold (0.21 log units) below the measured number, and the stated range covers the measured number.
By their numbers in this assay, from the lowest: compounds 1 and 3 (each within the scatter of the next); then compounds 4 and 2 (each within the scatter of the next).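

In this assay, hydrogen in place of hydroxymethyl on a triple-bonded carbon gives a 1.5-fold lower number from compound 2 to compound 4 (0.19 log units; within the scatter) and so does not separate the two compounds at this position. The other end of compound 4 proves the more telling place: a group holding selenium on an aromatic carbon gives way to one holding sulfur in a 4.0-fold higher number from compound 1 to compound 4 (0.61 log units; beyond the scatter) on that same propargyl background. From the compounds shown here alone, whether an amine, a carboxylic acid or a longer chain on the triple-bonded carbon would shift the number stays open. Nothing available here explains the size of either step.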